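The source may report more compounds than this note shows. Statements on the series, on what has been measured and on what is new or still open speak of the compounds shown alone.

Measured compounds in a functional assay on SNB-75 cells (Homo sapiens) for inhibition, read by sulforhodamine B assay, with a stated time of 48 h, tested at 10 uM; on this read-out lower numbers stand for less inhibition and higher numbers for more inhibition at the one concentration tested (going by the name of the read-out):
- compound 1 `c1ccc(-c2cn3ccnc3c(-c3ccc4ncn(C5CCCCC5)c4c3)n2)cc1` gives 44.4%
- compound 2 `Brc1ccc(-c2cn3ccnc3c(-c3ccc4ncn(C5CCCCC5)c4c3)n2)cc1` gives 34.6%
- compound 3 `CCc1ccc(-c2cn3ccnc3c(-c3ccc4ncn(Cc5ccccc5)c4c3)n2)cc1` gives 29.3%

Compound 3 stands apart from compound 1, whose number in this assay is higher by a margin beyond the usual scatter, while its number and that of compound 2 lie within the scatter of each other, so no order between those two can be read.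

Compound 4 `Cc1cccc(-c2cn3ccnc3c(-c3ccc4ncn(Cc5ccccc5)c4c3)n2)c1` differs from compound 3 in one place: 3-methylphenyl in place of 4-ethylphenyl on an aromatic carbon. Within the data shown here, the only single-change step among the measured compounds is a number 9.8 percentage points lower from compound 1 to compound 2 (within the scatter), where a different substituent on the same outer phenyl ring gave a step within the scatter. Among the measured compounds shown here, no measured pair swaps one alkyl-substituted phenyl for another, so there is no direct precedent for this change. For the measured compounds named here, since the one comparable aryl-substituent step stayed within the scatter, the expected step of a number 2.7 percentage points higher from compound 3 to compound 4 (within the scatter) is likewise none beyond the scatter. Compound 4 is therefore estimated at 32% in this assay, with a range from 15% to 50%.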

Compound 4, a percentage reported as inhibition, at one concentration (the size of the read-out at that concentration, not a potency): 21.7%
Compound 4: the middle estimate sits 10.3 percentage points above what was measured; the measured number falls inside the stated range.
By their numbers in this assay, from the lowest: compounds 4, 3, 2 and 1 (each within the scatter of the next, the first and the last beyond it).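

In this assay, among these compounds, 3-methylphenyl in place of 4-ethylphenyl on this aromatic carbon of the shared core gives a number 7.6 percentage points lower from compound 3 to compound 4 (within the scatter), the first exchange here of one alkyl-substituted phenyl for another. This single step changes both the alkyl group and its place on the outer phenyl ring, so the effects of the two changes cannot be separated, and because the step lies within the usual scatter, neither compound can be ranked above the other. No measurement here offers an explanation for the step.
The compounds shown leave open how an amine or a carboxylic acid on this outer phenyl ring would compare with these small alkyl groups. Also open, on these data alone, is whether a longer chain, such as propyl or butyl, would move the inhibition beyond the scatter.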